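Swapping the amide of compound 3 for a sulfonamide

The source may report more compounds than this note shows. Statements on the series, on what has been measured and on what is new or still open speak of the compounds shown alone.

Compound 1, `COc1ccc(S(=O)(=O)Nc2ccc3oc(-c4ccc(NS(=O)(=O)c5cc(F)ccc5OC)cc4)nc3c2)cc1`, gives > 100000 nM in an ADME assay on FHC cells (Homo sapiens) for cytotoxicity, read by resazurin assay, with a stated time of 48 h (a lower number here means that less compound is tolerated, a higher number that more compound is tolerated), a limit of the assay rather than a number.
Compound 2, `O=S(=O)(Nc1ccc(-c2nc3cc(NS(=O)(=O)c4ccc(Br)cc4)ccc3o2)cc1)c1ccc(Br)cc1`, gives 18000 nM in this assay.
Compound 3, `COc1ccc(S(=O)(=O)Nc2ccc3oc(-c4ccc(NC(=O)c5ccc(Cl)s5)cc4)nc3c2)cc1`, gives > 100000 nM in this assay, again a limit and not a number.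

Compound 3 therefore stands at the limit, with no number of its own; of the three values shown, two sit at that limit, and only compound 2 has a measured number. The change to compound 4, `COc1ccc(S(=O)(=O)Nc2ccc3oc(-c4ccc(NS(=O)(=O)c5cc(Br)ccc5OC)cc4)nc3c2)cc1`, is (5-bromo-2-methoxyphenyl)sulfonyl in place of (5-chlorothiophen-2-yl)carbonyl on a nitrogen on an aromatic ring. For the measured compounds named here, the one measured step that touches the same place is a step that the two limits leave unreadable from compound 1 to compound 3; both ends are limits, so its size cannot be read, and the only fixed point is the limit of > 100000 nM in this assay, at which 2 of the 3 values shown sit. Compound 4 shares the sulfonamide pattern of compound 1 and compound 2, whose values bracket the range from a measured number up to the limit. Going by the values given here, no step in this assay is readable at the place that changes, so no shift beyond the scatter can be foreseen in either direction, and the expected step of a number no higher from compound 3 to compound 4 (the limit leaves the size open) is set near zero. Compound 4 is thus estimated at 100000 nM, within 30000 nM to 300000 nM, with a limit again the likeliest outcome.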

Compound 4, half-maximal cytotoxic concentration: > 100000 nM
Compound 4: a limit, no number (the forecaster's own chance of this, stated with the estimate: 60%); the middle value lies on the limit itself.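

Compound 4, like compound 1 and compound 3, ends at a limit of the assay and not at a number, so the steps joining these compounds cannot be read. The compounds shown leave open whether swapping the groups on that nitrogen changes tolerance at all in this assay, given where the values stop: the limit of > 100000 nM in this assay, at which 3 of the 4 values shown sit.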